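This account rests on a few compounds, and the source may have more. Where it says the series, first, only, none or still open, it means among the compounds named here.

Three compounds share a core in which two amide groups are joined through a short chain. Compound 1 `Nc1ccccc1NC(=O)CCCNCC(=O)Nc1ccc(Br)cc1` carries a 4-bromophenyl group on one amide nitrogen, and compound 3 `Nc1ccccc1NC(=O)CCCNCC(=O)Nc1cccc([N+](=O)[O-])c1` carries a 3-nitrophenyl group in the same place. Compound 2 `Cc1ccc(NC(=O)CNc2ccc(C(=O)Nc3ccccc3N)cc2)cc1` has a different link between the two amides. In a functional assay on HCT-116 cells (Homo sapiens) for inhibition, read by MTT assay, with a stated time of 2 days (a higher number here means a weaker inhibitor of growth, a lower number a stronger inhibitor of growth), compound 1 gives 55500 nM. In this assay compound 3 gives 22500 nM. For compound 2 this assay reached only a limit, > 100000 nM, which is the limit of > 100000 nM in this assay, at which 1 of the 3 values shown sits. Compound 3 therefore stands lowest of the two numbers actually obtained, set apart from compound 1 by the only one-place step among these compounds, a 2.5-fold lower number from compound 1 to compound 3 (0.39 log units; beyond the scatter), a modest move.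

Compound 4 `Nc1ccccc1NC(=O)CCCNCC(=O)Nc1cccc(Cl)c1` differs from compound 3 in one place: chloro in place of nitro on an aromatic carbon. Going by the values given here, no measured step swaps nitro for chloro on the same ring carbon. Among the compounds with values here, the one related step, a 2.5-fold lower number from compound 1 to compound 3 (0.39 log units; beyond the scatter), lowered the number when a halogen-bearing ring gave way to the nitro-bearing ring. Putting a halogen back, even at a different position on the ring, is expected to move the number partly back toward that of compound 1, so a modest rise, a 1.8-fold higher number from compound 3 to compound 4 (0.25 log units; within the scatter), is expected. Compound 4 is estimated at 40000 nM, within a range from 15000 nM to 100000 nM.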

Compound 4, concentration for total growth inhibition: 75000 nM
Beside the measured number, compound 4's estimate is 1.9-fold (0.27 log units) below it, and the stated range covers the measured number.
By their numbers in this assay, from the lowest: compound 3; then compounds 1 and 4 (each within the scatter of the next). At a limit, above all of these: compound 2.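

The earlier step on this ring changed the group and its place together, whereas here the place stays the same, on an aromatic carbon meta to a large group, and only the group changes. That single change gives a 3.3-fold higher number from compound 3 to compound 4 (0.52 log units; beyond the scatter) in this assay, so nitro and chloro are not interchangeable at this ring carbon. The two halogen-bearing compounds, by contrast, cannot be told apart, with a 1.4-fold higher number from compound 1 to compound 4 (0.13 log units; within the scatter), leaving compound 3 as the one of these three that stands clear of the others, although nothing given here explains why nitro and chloro differ in this way.

Still open, from the compounds shown here alone, is where an amine or a carboxylic acid at the same ring carbon would fall relative to nitro and chloro. Also open, going by these compounds, is how a 4-nitrophenyl group would compare with the 4-bromophenyl group of compound 1, a pair that would test the same group swap at the other ring place.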